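The compounds below may be only part of what the source reports. "The series", "measured", "known", "first", "only" and "open" are said of these compounds alone.

Working notes on an ADME assay on microsomes from liver (Rattus norvegicus) for metabolic stability; on this read-out lower numbers stand for slow clearance and higher numbers for fast clearance. Compound 1 (`CNc1nc(NC2(C#N)CCCCC2)nc(N2CCCC2)n1`) gives > 276 mL/min/kg, which is a limit of the assay and not a number. For the measured compounds named here, compound 2 (`CNc1nc(NC2(C#N)CCCCC2)nc(-n2cnc(C#N)n2)n1`) gives 210 mL/min/kg, the only actual number so far. Compound 3 (`CNc1nc(C#N)nc(NC2(C#N)CCCCC2)n1`) differs from compound 2 by cyano in place of 3-cyano-1H-1,2,4-triazol-1-yl on an aromatic carbon. Going by the values given here, the one measured step at this aromatic carbon is an at least 1.3-fold lower number from compound 1 to compound 2 (0.11 log units; that floor lies within the scatter), and its floor lies within the scatter. No step beyond the scatter is therefore expected, and the estimated step is a 1.3-fold lower number from compound 2 to compound 3 (0.12 log units; within the scatter). Compound 3 is expected at 160 mL/min/kg, with an estimated range of 70 mL/min/kg to 276 mL/min/kg.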

Compound 3, clearance: 122 mL/min/kg
For compound 3 the middle estimate is 1.3-fold (0.12 log units) above the measured one, and the stated range covers the measured number.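

In this assay, for the compounds shown here, cyano in place of pyrrolidin-1-yl on this aromatic carbon gives an at least 2.2-fold lower number from compound 1 to compound 3 (0.35 log units; beyond the scatter), the only step at this position that clears the scatter. Compound 1 stands at a limit of the assay, so that step is only a floor: the limit of > 276 mL/min/kg in this assay, at which 1 of the 3 values shown sits. Cyano in place of 3-cyano-1H-1,2,4-triazol-1-yl gives a 1.7-fold lower number from compound 2 to compound 3 (0.24 log units; within the scatter), so the five-membered ring can be exchanged for cyano without a step beyond the scatter.

Still open, from the compounds shown here alone, is how a primary amine or a methoxy group on this aromatic carbon would read in this assay. Also open, going by these compounds, is how far changes elsewhere on the shared core would move clearance.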